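Thiophen-2-yl to thiophen-3-yl: a small step expected

This account rests on a few compounds, and the source may have more. Where it says the series, first, only, none or still open, it means among the compounds named here.

Compound 1 `COc1ccc(OC)c(C(=O)/C=C/c2ccco2)c1`: 24800 nM
Compound 2 `COc1ccc(OC)c(C(=O)/C=C/c2cccs2)c1`: 13300 nM

For the measured compounds named here, in a functional assay on HT-29 cells (Homo sapiens) for cytotoxicity, read by MTT assay (on this read-out lower numbers stand for stronger inhibition and higher numbers for weaker inhibition), compound 2 lies within the usual scatter of compound 1, the only other compound measured. Compound 3 `COc1ccc(OC)c(C(=O)/C=C/c2ccsc2)c1` has the same atoms as compound 2, joined differently: thiophen-3-yl in place of thiophen-2-yl on a double-bonded chain carbon bound to a double-bonded chain carbon. Going by the values given here, the one measured step that bears on this, a 1.9-fold lower number from compound 1 to compound 2 (0.27 log units; within the scatter), also exchanged the ring at this place and stayed small. Among the compounds with values here, no measured pair shows this exact change, so no step beyond the scatter is expected, in either direction. The expected step is a 1.1-fold higher number from compound 2 to compound 3 (0.05 log units; within the scatter). For compound 3 the estimated value is 15000 nM, with an expected range of 7000 nM to 32000 nM.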

Compound 3, half-maximal inhibitory concentration: 5300 nM
Estimate against measurement, compound 3: 2.8-fold (0.45 log units) above; the measured number lies below the stated range.
By their numbers in this assay, from the lowest: compound 3; then compounds 2 and 1 (each within the scatter of the next).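

In this assay swapping thiophen-2-yl for thiophen-3-yl gives a 2.5-fold lower number from compound 2 to compound 3 (0.40 log units; beyond the scatter) with no atom gained or lost, so at this place how the ring is joined matters, not only which ring it is. Exchanging furan-2-yl for thiophen-3-yl gives a 4.7-fold lower number from compound 1 to compound 3 (0.67 log units; beyond the scatter) and also lies beyond the scatter, which the earlier ring exchange did not. Nothing available here accounts for the difference. The compounds shown leave open how a furan-3-yl or a phenyl group would behave at this place, and whether a methyl group on the thiophen-3-yl ring would lower the number further.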